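The source may report more compounds than this note shows. Statements on the series, on what has been measured and on what is new or still open speak of the compounds shown alone.

Of the compounds shown here, two have been measured in an assay on cell membranes for displacement of a labelled ligand from corticotropin-releasing factor receptor 1 (Rattus norvegicus); a lower number here means a stronger inhibitor, a higher number a weaker inhibitor. Compound 1 `CCCN(C)c1nc(C)nc2c(-c3c(C)cc(OC)cc3OC)c(C)nn12` gives 6.48 nM. Compound 2 `CCCCN(CC)c1nc(C)nc2c(-c3ccc(OC)cc3C)c(C)nn12` gives 2.3 nM, the lowest of the two numbers; the gap from compound 1 to compound 2 lies beyond the usual scatter, so compound 2 is the stronger inhibitor of the pair. The two also differ at more than one place, so the number alone cannot say which part of the structure carries the difference.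

Compound 3 `CCCCN(CC)c1nc(C)nc2c(-c3c(C)cc(OC)cc3OC)c(C)nn12` is built from compound 2 by one change: methoxy in place of hydrogen on an aromatic carbon. With this addition, the aromatic ring of compound 3 becomes the same as that of compound 1, while the chains on the amine stay those of compound 2. Going by the values given here, no measured pair shows the effect of this single change on its own. Because compound 1, which carries this ring, gives 6.48 nM, a modest weakening relative to compound 2 seems more likely than a gain, though a step within the scatter is equally plausible. Compound 3 is therefore expected to give about 3.5 nM, most likely between 1.2 nM and 10 nM, a step of a 1.5-fold higher number from compound 2 to compound 3 (0.18 log units; within the scatter) that is expected to be small.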

Compound 3, half-maximal inhibitory concentration: 1.72 nM
Compound 3: the middle estimate sits 2.0-fold (0.31 log units) above what was measured; the range from low to high includes it.
By their numbers in this assay, from the lowest: compounds 3 and 2 (each within the scatter of the next); then compound 1.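

Methoxy in place of hydrogen is accepted at this position, ortho to a large group: in this assay the change gives a 1.3-fold lower number from compound 2 to compound 3 (0.13 log units; within the scatter), so the added group makes no difference that can be told from the scatter. Going by these compounds alone, the amine chains can now be read on their own for the first time, since compound 1 and compound 3 share the same aromatic ring, and butyl(ethyl)amino in place of methyl(propyl)amino gives a 3.8-fold lower number from compound 1 to compound 3 (0.58 log units; beyond the scatter), a modest step but a real one, which places the clearer difference at the amine rather than at this methoxy. No measurement is at hand that explains either step.

Each change has been read only once, so the methoxy result holds with the butyl(ethyl)amino chains and the amine result holds with the methoxy-bearing ring, and neither is known to carry over to other partners. On these data alone, it remains open how this position would respond to a different group such as ethoxy, hydroxy or chlorine, and whether a different amine such as dibutylamino would take the step at the chains further.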